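The source may report more compounds than this note shows. Statements on the series, on what has been measured and on what is new or still open speak of the compounds shown alone.

Values measured in an ADME assay on MCF7-DOX cells (Homo sapiens) for cytotoxicity, read by MTT assay, with a stated time of 48 h; on this read-out higher numbers stand for weaker inhibition and lower numbers for stronger inhibition:

- compound 1 `COc1cccc(/C=C/C(=O)c2c(OC)cc(OC)c(CC=C(C)C)c2O)c1` gives 49200 nM
- compound 2 `COc1cc(OC)c(C(=O)/C=C/c2cccc(C(F)(F)F)c2)c(O)c1CC=C(C)C` gives 66600 nM
- compound 3 `COc1cc(OC)c(C(=O)/C=C/c2ccc(Cl)cc2)c(O)c1CC=C(C)C` gives 43400 nM

The three compounds are not separated by these numbers. Compound 3, at 43400 nM, lies within the scatter of both others, as the steps to it show: a 1.1-fold lower number from compound 1 to compound 3 (0.05 log units; within the scatter) and a 1.5-fold lower number from compound 2 to compound 3 (0.19 log units; within the scatter). The remaining step, a 1.4-fold higher number from compound 1 to compound 2 (0.13 log units; within the scatter), is no larger in any meaningful sense.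

The next compound is compound 4 `COc1cc(OC)c(C(=O)/C=C/c2ccc(F)cc2)c(O)c1CC=C(C)C`, which departs from compound 3 by a single exchange: fluoro in place of chloro on an aromatic carbon. It is fluoro in place of chloro on an aromatic carbon, para to a large group, so 4-chlorophenyl becomes 4-fluorophenyl.

For the measured compounds named here, no measured step makes this exact exchange. The nearest evidence comes from the steps that replace the whole aryl group at this same place, and even those changes, a 1.1-fold lower number from compound 1 to compound 3 (0.05 log units; within the scatter) and a 1.5-fold lower number from compound 2 to compound 3 (0.19 log units; within the scatter), stayed within the scatter. A smaller edit at that place is therefore expected to leave the number about where it is, with no shift beyond the scatter in either direction.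

The estimated step is a 1.1-fold higher number from compound 3 to compound 4 (0.04 log units; within the scatter).

For compound 4 the estimated value is 48000 nM, with an expected range from 26000 nM to 85000 nM.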

Compound 4, half-maximal inhibitory concentration: 53700 nM
Compound 4: the middle estimate sits 1.1-fold (0.05 log units) below what was measured; measured number inside the range.
By their numbers in this assay, from the lowest: compounds 3, 1, 4 and 2 (each within the scatter of the next).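

The earlier compounds shown here changed the whole aryl group, whereas this pair changes a single halogen on the aromatic carbon para to a large group. In this assay, for the compounds shown here, chloro and fluoro cannot be told apart at this place, with a 1.2-fold higher number from compound 3 to compound 4 (0.09 log units; within the scatter) as the only direct reading of this exchange. The whole-group comparisons read the same way, with a 1.2-fold lower number from compound 2 to compound 4 (0.09 log units; within the scatter) and a 1.1-fold higher number from compound 1 to compound 4 (0.04 log units; within the scatter), so 4-fluorophenyl joins 4-chlorophenyl, 3-methoxyphenyl and 3-(trifluoromethyl)phenyl as a set of aryl groups that this read-out does not separate, and no available evidence offers an explanation for how closely these numbers lie.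

The compounds shown leave open whether any group at this aromatic carbon would give a step beyond the scatter, for instance an amine or a carboxylic acid in place of the halogen. They also leave open whether the number responds to edits away from this aryl group, such as a longer chain in place of the one on the shared core, since only the aryl group varies among these four compounds.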